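Methyl for methoxy on two indole cores

This account rests on a few compounds, and the source may have more. Where it says the series, first, only, none or still open, it means among the compounds named here.

The first pair shares one core: compound 1 `COc1ccc2[nH]c(-c3ccc[nH]3)c(C3CC(=O)NC3=O)c2c1` and compound 3 `Cc1ccc2[nH]c(-c3ccc[nH]3)c(C3CC(=O)NC3=O)c2c1`. In a functional assay on OE21 cells (Homo sapiens) for cytotoxicity, read by MTT assay, with a stated time of 72 h (on this read-out lower numbers stand for stronger inhibition and higher numbers for weaker inhibition), compound 1 gives 53000 nM. For compound 3 this assay reports only a limit, > 100000 nM. The change is methyl in place of methoxy on an aromatic carbon and the step it made is an at least 1.8-fold higher number from compound 1 to compound 3 (0.27 log units; that floor lies within the scatter). The second pair rests on a different core, and the difference between the two cores is not broken down here. For compound 2 `COc1ccc2[nH]c(-n3cccn3)cc2c1` this assay again reports only a limit, > 100000 nM. Compound 4 `Cc1ccc2[nH]c(-n3cccn3)cc2c1` is still to be measured, and its change from compound 2 is the same one, (methyl in place of methoxy on an aromatic carbon). Since the limit of > 100000 nM in this assay, at which 2 of the 3 values shown sit, already sits on compound 2, a further rise in number would stay beyond it, and the estimated step is a step that the limit leaves unreadable from compound 2 to compound 4. Compound 4 is therefore expected to give 150000 nM, between 100000 nM and 300000 nM.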

Compound 4, half-maximal inhibitory concentration: > 100000 nM
Compound 4 gave a limit, no number; the forecaster's own chance of this, stated with the estimate: 85%; the middle value is on the limit's open side.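

Compound 2 and compound 4 both give only a limit, so no step can be read between them: the limit of > 100000 nM in this assay, at which 3 of the 4 values shown sit.

From the compounds shown here alone, what methyl in place of methoxy does on the core of compound 2 stays open.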